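Replacing the Ring Head on a Fatty Ketone Inhibitor

This account rests on a few compounds, and the source may have more. Where it says the series, first, only, none or still open, it means among the compounds named here.

Three compounds have been tested in an assay on isolated protein for inhibition of Fatty-acid amide hydrolase 1 (Homo sapiens); a lower number here means a stronger inhibitor, a higher number a weaker inhibitor:

Compound 1 `CCCCCCCCCCCCCC(=O)C(F)(F)F` gives 490 nM.
Compound 2 `CCCCCCCC/C=C\CCCCCCC(=O)c1nc2ncccc2o1` gives 2.3 nM.
Compound 3 `CCCCCCCC/C=C\CCCCCCC(=O)c1ncc(-c2ccccn2)o1` gives 18 nM.

All three share a long hydrocarbon chain ending in a carbonyl; what differs is the group attached on the other side of that carbonyl. Compound 2 gives the lowest of the three numbers and is the strongest inhibitor here. Compound 3 stands nearest to it and compound 1 furthest, and both gaps lie beyond the usual scatter of repeated measurements.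

Compound 4 `CCCCCCCC/C=C\CCCCCCC(=O)c1nc2ccccc2o1` has not yet been measured. It keeps everything of compound 2 except the ring group on the carbonyl carbon: a group of 9 heavy atoms (7 carbon, 1 nitrogen, 1 oxygen; one five-membered aromatic ring with 2 hetero atoms, one six-membered aromatic ring of carbon only) in place of a group of 9 heavy atoms (6 carbon, 2 nitrogen, 1 oxygen; one five-membered aromatic ring with 2 hetero atoms, one six-membered aromatic ring with 1 hetero atom), on a carbonyl carbon.

Within the data shown here, no measured pair isolates this particular change, so the expectation rests on compound 2, which carries the leaving group and is the best of the three. Taking away part of what sets it apart seems more likely to cost than to gain. A moderate step toward weaker inhibition is expected, a 6.5-fold higher number from compound 2 to compound 4 (0.81 log units; beyond the scatter), though a step within the scatter cannot be excluded. Compound 4 is therefore estimated at 15 nM, with a likely range from 4 nM to 60 nM.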

Compound 4, inhibition constant: 370 nM
Compound 4: middle estimate off by 25-fold (1.39 log units), on the low side, outside the stated range (above it).
By their numbers in this assay, from the lowest: compound 2; then compound 3; then compounds 4 and 1 (each within the scatter of the next).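

In this assay, changing the ring group on the carbonyl carbon to 1,3-benzoxazol-2-yl gives a 160-fold higher number from compound 2 to compound 4 (2.21 log units; beyond the scatter). The two groups have the same number of heavy atoms and the same ring sizes; what differs is that a nitrogen in the six-membered ring becomes carbon, taking the count of hydrogen-bond acceptors from 3 to 2. This position is therefore far more sensitive than the similar shape of the two groups would suggest, with the nitrogen-containing six-membered ring being what keeps compound 2 in the low nanomolar range, and no measurement shown here explains why this one atom matters so much.

The compounds shown leave open whether a second nitrogen in the six-membered ring of compound 2 would strengthen inhibition further, or whether a fluorine or a methoxy group on the carbon-only ring of compound 4 would win back any of the loss. They also leave open whether a step of this size would appear with a saturated chain in place of the unsaturated one.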